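This account rests on a few compounds, and the source may have more. Where it says the series, first, only, none or still open, it means among the compounds named here.

For the measured compounds named here, compound 1 `CCOC(=O)[C@@H]1CCC[C@H](S(=O)(=O)c2ccc(S(=O)(=O)N(CC)CC)cc2)C1` and compound 2 `CCN(CC)S(=O)(=O)c1ccc(S(=O)(=O)N2CCC[C@@H](C(=O)N3CCN(C(=O)OC(C)(C)C)CC3)C2)cc1` are the two compounds so far tested in a functional assay on MIA PaCa-2 cells (Homo sapiens) for inhibition, read by MTT assay, with a stated time of 3 days; on this read-out lower numbers stand for stronger inhibition and higher numbers for weaker inhibition. For compound 1 this assay reports only a limit, > 10000 nM. For compound 2 this assay likewise reports only a limit, > 10000 nM. Going by the values given here, compound 2 thus stands at the same limit as the only other value shown, since both values sit at the limit of > 10000 nM in this assay, at which 2 of the 2 values shown sit, and no step between measured compounds can be read from them.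

Compound 3 `CCN(CC)S(=O)(=O)c1ccc(S(=O)(=O)N2CCC[C@@H](C(=O)N3CCN(c4nnc(C(C)C)o4)CC3)C2)cc1` differs from compound 2 in one place: 5-isopropyl-1,3,4-oxadiazol-2-yl in place of tert-butoxycarbonyl on an amine nitrogen in a ring. Nothing measured shows what this change does, so the direction of the step is open; a new aromatic ring in place of a carbamate is a sizeable change, and the expected step is an at least 3.3-fold lower number from compound 2 to compound 3 (0.52 log units; beyond the scatter). Compound 3 is expected to give about 3000 nM in this assay, within 300 nM to 10000 nM, with a real chance that again only a limit is reported.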

Compound 3, half-maximal inhibitory concentration: > 10000 nM
Compound 3: only a limit was reported (the forecaster's own chance of this, stated with the estimate: 40%); middle value at least 3.3-fold (0.52 log units) from the limit.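

Compound 3, like compound 2, stands only at a limit, so no step can be read between them: the limit of > 10000 nM in this assay, at which 3 of the 3 values shown sit.

The compounds shown leave open what 5-isopropyl-1,3,4-oxadiazol-2-yl does in place of tert-butoxycarbonyl, and which change to the shared core, if any, would give a readable value.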